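The compounds below may be only part of what the source reports. "The series", "measured", "known", "first", "only" and "open" are said of these compounds alone.

Of the compounds shown here, three have been measured in a functional assay on A-375 cells (Homo sapiens) for inhibition, read by CCK-8 assay, with a stated time of 72 h, tested at 8 uM (on this read-out higher numbers stand for more inhibition of growth at the one concentration tested and lower numbers for less inhibition of growth), so far, and compound 3 `Cc1ccc(SCc2ccc(/C=C/C(=O)Nc3ccccc3N)cc2)cc1` stands lowest with 31.2% on this scale, against compound 1 `COc1ccc(SCc2ccc(/C=C/C(=O)Nc3ccccc3N)cc2)cc1OC` with 46.4% and compound 2 `CCc1ccc(SCc2ccc(/C=C/C(=O)Nc3ccccc3N)cc2)cc1` with 58.4% in the same test. The next structure, compound 4 `Nc1ccccc1NC(=O)/C=C/c1ccc(CSCCc2ccccc2)cc1`, carries phenethyl in place of 4-methylphenyl on a sulfur. Going by the values given here, two measured steps bear on this change: one swaps the whole group on the sulfur (a number 15.2 percentage points lower from compound 1 to compound 3 (beyond the scatter)), and the other puts hydrogen in place of methyl on that group (a number 27.2 percentage points lower from compound 2 to compound 3 (beyond the scatter)). Among the compounds with values here, both are modest, yet no measured compound carries phenethyl, so the direction remains uncertain. A modest rise is expected (a number 9.8 percentage points higher from compound 3 to compound 4 (within the scatter)). Compound 4 is estimated at 41% (expected range 24% to 58%).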

Compound 4, percent growth inhibition at one concentration: 37.4%
Compound 4: the middle estimate sits 3.6 percentage points above what was measured, and the stated range covers the measured number.
By their numbers in this assay, from the lowest: compounds 3, 4 and 1 (each within the scatter of the next, the first and the last beyond it); then compound 2.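

In this assay, phenethyl on a sulfur shows no clear change against 4-methylphenyl (a number 6.2 percentage points higher from compound 3 to compound 4 (within the scatter)) or 3,4-dimethoxyphenyl (a number 9 percentage points lower from compound 1 to compound 4 (within the scatter)), but it falls short of 4-ethylphenyl (a number 21 percentage points lower from compound 2 to compound 4 (beyond the scatter)). Compound 2 therefore stands clear of all three other compounds, and phenethyl does not reach its level even though it is a larger group than 4-methylphenyl. No measured evidence here explains these differences. Still open, from the compounds shown here alone, is how a longer chain, such as 3-phenylpropyl, or an amine on the sulfur-bound group would compare.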